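The compounds below may be only part of what the source reports. "The series", "measured", "known", "first", "only" and "open" are said of these compounds alone.

In an ADME assay on Huh-7 cells (Homo sapiens) for cytotoxicity (on this read-out higher numbers stand for lower toxicity in this test and lower numbers for higher toxicity in this test), compound 2, `Cc1ccccc1-c1nn(Cc2ccc(F)cc2)cc1CNCCN1CCN(C)CC1`, reports only a limit, > 20000 nM. Compound 1, `Cc1ccccc1CNc1nn(-c2ccc(F)cc2F)cc1CNCCN1CCN(C)CC1`, likewise reaches only a limit in this assay, > 20000 nM. Compound 3, `CCCN1CCC(CNCc2cn(-c3ccc([N+](=O)[O-])cc3)nc2-c2ccc(C(F)(F)F)cc2)CC1`, gives a number in this assay, 2300 nM. Two of the three values therefore sit together at the ceiling, (the limit of > 20000 nM in this assay, at which 2 of the 3 values shown sit). Compound 4, `CCOC(=O)Cn1cc(CNCCN2CCN(C)CC2)c(-c2ccccc2C)n1`, has not yet been measured in this assay. It differs from compound 2 in one place: ethoxycarbonyl in place of 4-fluorophenyl on a saturated chain carbon bound to an aromatic nitrogen. Going by the values given here, no measured pair differs in a single place, so the size of this kind of step is not known from the data. The step expected here, a step that the limit leaves unreadable from compound 2 to compound 4, is none beyond the scatter, with a limit again the most likely outcome. Compound 4 is thus expected at 25000 nM in this assay, within a range from 10000 nM to 60000 nM.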

Compound 4, half-maximal cytotoxic concentration: > 20000 nM
Compound 4 ended at the assay's limit; the forecaster's own chance of this, stated with the estimate: 70%; the middle value is on the limit's open side.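

No step can be read from compound 2 to compound 4 in this assay, as both end at a limit: the limit of > 20000 nM in this assay, at which 3 of the 4 values shown sit. The compounds shown leave open whether 4-fluorobenzyl and (ethoxycarbonyl)methyl differ at all in this read-out.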